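Dropping a Methyl Group: From Compound 3 to Compound 4

The compounds below may be only part of what the source reports. "The series", "measured", "known", "first", "only" and "open" are said of these compounds alone.

Compound 1, `Cc1nnc(SCC(=O)c2ccccc2)n1N1C(=O)c2ccccc2C1=O`, gives > 200000 nM in a functional assay on A549 cells (Homo sapiens) for cytotoxicity, read by MTT assay, with a stated time of 48 h; a higher number here means a weaker inhibitor, a lower number a stronger inhibitor. Compound 2, `CCCc1nnc(SCC(=O)c2ccc(Cl)cc2)n1N1C(=O)c2ccccc2C1=O`, gives > 200000 nM in this assay. Compound 3, `CCCc1nnc(SCC(=O)c2ccc(C)cc2)n1N1C(=O)c2ccccc2C1=O`, gives > 200000 nM in this assay.

Each of these three values is a limit of the assay, not a number. Compound 3 therefore stands at a limit in this assay, and it shares that standing with the other two compounds, as the limit of > 200000 nM in this assay, at which 3 of the 3 values shown sit, records. Going by the values given here, the only step that can be drawn among the measured compounds, a step that the two limits leave unreadable from compound 2 to compound 3, is unreadable because both of its ends are limits.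

Compound 4, `CCCc1nnc(SCC(=O)c2ccccc2)n1N1C(=O)c2ccccc2C1=O`, differs from compound 3 by hydrogen in place of methyl on an aromatic carbon. Among the compounds with values here, no measured step bears directly on this change, and the one step that exists gives no size. What the data do show is that three compounds with varied substituents on the aromatic ring of the ketone, and with either methyl or propyl on the core, all remain at the limit in this assay.

On that basis compound 4 is expected to remain at the limit as well, with an estimated value of 300000 nM, ranging from 150000 nM to 1000000 nM. The expected step is a step that the limit leaves unreadable from compound 3 to compound 4, which is not expected to be beyond the scatter.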

Compound 4, half-maximal inhibitory concentration: > 200000 nM
Compound 4 ended at the assay's limit; the forecaster's own chance of this, stated with the estimate: 90%; the middle value lies beyond the limit too.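

In this assay compound 4 gives > 200000 nM, which is a limit of the assay and not a number. No step from compound 1, compound 2 or compound 3 to compound 4 can be read, because both ends of each are limits: the limit of > 200000 nM in this assay, at which 4 of the 4 values shown sit.

The compounds shown leave open what size these changes have, and whether any close relative gives a readable value in this assay.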